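From methyl to acetamido on an aromatic carbon

A few compounds are considered here, and "the series" means these few. Any claim that something is new, unique, unknown or untested is made for them only; others in the source may bear on it.

In a functional assay on NZB5 cells (Homo sapiens) for inhibition, read by thymidine incorporation, with a stated time of 5 days (on this read-out lower numbers stand for stronger inhibition and higher numbers for weaker inhibition), compound 1 (`Cc1ccc(C)c(S(=O)(=O)N(C)/N=C/c2cnn3ccc(C#N)cc23)c1`) gives 2100 nM. Among the compounds with values here, this is the higher of the two numbers available so far, since compound 2 (`CN(/N=C/c1cnn2ccc(C#N)cc12)S(=O)(=O)c1cc([N+](=O)[O-])ccc1F`), with other substituents on the same core, gives 480 nM, a gap beyond the usual scatter. Compound 3 (`CC(=O)Nc1ccc(C)c(S(=O)(=O)N(C)/N=C/c2cnn3ccc(C#N)cc23)c1`) has not yet been measured. It differs from compound 1 in one place: acetamido in place of methyl on an aromatic carbon. Acetamido stands in place of methyl on an aromatic carbon, meta to a large group and para to a methyl group. Within the data shown here, no measured pair isolates this change, so the expectation rests on little. Compound 2, at 480 nM, shows only that other substituents on that ring can go with a lower number. A modest shift towards stronger inhibition is therefore expected, possibly no larger than the scatter. The expected change is a 1.8-fold lower number from compound 1 to compound 3 (0.24 log units; within the scatter). For compound 3 the estimated value is 1200 nM, with an expected range of 300 nM to 4500 nM.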

Compound 3, half-maximal inhibitory concentration: > 20000 nM
Compound 3: only a limit was reported (the forecaster's own chance of this, stated with the estimate: 5%); middle value at least 16-fold (1.22 log units) away from the limit.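

In this assay, compound 3 is reported only as a limit of the assay, not as a number: the limit of > 20000 nM in this assay, at which 1 of the 3 values shown sits. Even so, acetamido in place of methyl on this aromatic carbon, meta to a large group and para to a methyl group, gives an at least 9.5-fold higher number from compound 1 to compound 3 (0.97 log units; beyond the scatter), which means much weaker inhibition. The position therefore does not accept every change in the same way, something compound 2, with other substituents on that ring, could not show.

Going by these compounds, how far the acetamido compound lies past the limit stays open, as does which part of the group, the carbonyl or the amide hydrogen, goes with the loss. Also open, on these data alone, is how a simple amine or a methoxy group would read at this same position on the shared core.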